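The source may hold more compounds than are shown below. What is called first, only, known or untested is meant among the compounds shown, and "the series" means these compounds.

Compound 3 `O=C(O)Cc1sc(C(c2ccc(F)cc2)c2ccc(F)cc2)nc1-c1cccc(F)c1` gives the lowest number among the three measured compounds in an in vitro functional assay on HEK285-7 cells for antagonist activity at prostaglandin D2 receptor 2 (Homo sapiens), read by BRET and beta-arrestin recruitment (on this read-out higher numbers stand for weaker inhibition and lower numbers for stronger inhibition), where compound 3 gives 18 nM. Compound 1 `O=C(O)Cc1sc(C(c2ccc(F)cc2)c2ccc(F)cc2)nc1-c1ccc(Cl)cc1` gives 180 nM, and compound 2 `O=C(O)Cc1sc(C(c2ccc(F)cc2)c2ccc(F)cc2)nc1-c1ccccc1` gives 240 nM. The step of a 1.3-fold higher number from compound 1 to compound 2 (0.12 log units; within the scatter) lies within the scatter, whereas a 10-fold lower number from compound 1 to compound 3 (1.00 log units; beyond the scatter) and a 13-fold lower number from compound 2 to compound 3 (1.12 log units; beyond the scatter) both stand beyond it. Compound 4 `O=C(O)Cc1sc(C(c2ccc(F)cc2)c2ccc(F)cc2)nc1-c1cc(F)cc(F)c1` differs from compound 3 by fluoro in place of hydrogen on an aromatic carbon. The closest measured precedent, also a fluoro in place of hydrogen on an aromatic carbon, is a 13-fold lower number from compound 2 to compound 3 (1.12 log units; beyond the scatter), a large drop. A second fluoro of the same kind need not repeat that gain in full, and the step of a 1.3-fold higher number from compound 1 to compound 2 (0.12 log units; within the scatter) is a reminder that a change on an aromatic carbon can leave the number unmoved. The expectation is therefore a small further lowering at most, possibly none beyond the scatter, so that compound 4 is estimated to show a 1.5-fold lower number from compound 3 to compound 4 (0.18 log units; within the scatter). Compound 4 is expected to give 12 nM in this assay, with a range from 4 nM to 40 nM.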

Compound 4, half-maximal inhibitory concentration: 340 nM
Beside the measured number, compound 4's estimate is 28-fold (1.45 log units) below it; the whole stated range lies below it.
By their numbers in this assay, from the lowest: compound 3; then compounds 1, 2 and 4 (each within the scatter of the next).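

In this assay the same exchange, fluoro in place of hydrogen on an aromatic carbon, does not act the same way twice: against a 13-fold lower number from compound 2 to compound 3 (1.12 log units; beyond the scatter) stands a 19-fold higher number from compound 3 to compound 4 (1.28 log units; beyond the scatter), a reversal of about the same size. The 3,5-difluorophenyl group thus gives up the whole gain of the 3-fluorophenyl group, since a 1.4-fold higher number from compound 2 to compound 4 (0.15 log units; within the scatter) and a 1.9-fold higher number from compound 1 to compound 4 (0.28 log units; within the scatter) both leave the number where the phenyl and 4-chlorophenyl groups had it, so the effect of a fluoro on this ring depends on what the ring already carries. Nothing available accounts for this reversal.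

From the compounds shown here alone, it remains open whether a methyl or a methoxy group in that same place, meta to a fluoro group, would keep the low number of compound 3 or lose it as the second fluoro does. Going by these compounds, it is equally open whether the steep change is tied to fluoro itself or would also appear with a larger group such as an amine.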